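The compounds below may be only part of what the source reports. "The series", "measured", "known", "first", "only" and "open" are said of these compounds alone.

Of the compounds shown here, three sharing one core have been tested in a functional assay on ECa-109 cells for inhibition, with ECa-109 cell line (Homo sapiens) as the target, read by sulforhodamine B assay; on this read-out higher numbers stand for weaker inhibition and lower numbers for stronger inhibition. Compound 1 `O=C1C=C(Nc2ccc(I)cc2)C(=O)c2c1nc1n2[C@H]2OC[C@@H](O)[C@H]2OC1` gives 2300 nM. Compound 2 `Cc1ccc(NC2=CC(=O)c3nc4n(c3C2=O)[C@H]2OC[C@@H](O)[C@H]2OC4)cc1C` gives 2820 nM. Compound 3 `O=C1C(Nc2cccc(Cl)c2)=CC(=O)c2c1nc1n2[C@H]2OC[C@@H](O)[C@H]2OC1` gives 3080 nM, a number that lies within the scatter of both compound 1 and compound 2, so the three cannot be told apart. The step from compound 3 leads to compound 4 `COc1ccc(NC2=CC(=O)c3c(nc4n3[C@H]3OC[C@@H](O)[C@H]3OC4)C2=O)cc1`, where the change is 4-methoxyphenyl in place of 3-chlorophenyl on an amine nitrogen. Going by the values given here, only one measured step bears on swapping the group on the amine nitrogen: a 1.2-fold higher number from compound 1 to compound 2 (0.09 log units; within the scatter), which did not move the number beyond the scatter. Since every aryl change seen so far left this assay unchanged, compound 4 is expected to sit close to compound 3, with an estimated step of a 1.1-fold lower number from compound 3 to compound 4 (0.04 log units; within the scatter). The estimate for compound 4 is therefore 2800 nM, expected to fall between 1400 nM and 5600 nM.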

Compound 4, half-maximal inhibitory concentration: 3410 nM
Beside the measured number, compound 4's estimate is 1.2-fold (0.09 log units) below it; the range from low to high includes it.
By their numbers in this assay, from the lowest: compounds 1, 2, 3 and 4 (each within the scatter of the next).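

In this assay, the exchange of 3-chlorophenyl for 4-methoxyphenyl on the amine nitrogen gives a 1.1-fold higher number from compound 3 to compound 4 (0.04 log units; within the scatter). This adds a second measured step at this position, now with chlorine gone and an oxygen-bearing methoxy group in its place, and again the numbers cannot be told apart. Nothing available explains why this change leaves the number within the scatter.

All four compounds carry a substituted phenyl ring on this nitrogen. On these data alone, it remains open whether a group without that ring, such as a cyclohexyl ring or a longer chain ending in an amine or a carboxylic acid, would move the number beyond the scatter.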